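The compounds below may be only part of what the source reports. "The series", "measured", "known", "first", "only" and "open" are said of these compounds alone.

Compound 3 `O=C(O)CCC1=C(c2ccccc2)NC(=S)NC1c1ccccc1O` gives 33% in a functional assay on the whole organism (strain Albino) for inhibition, with Rattus norvegicus as the target, with a stated time of 1 h, at a dose of 20 mg/kg by the oral route (a higher number here means more inhibition at the dose given (going by the name of the read-out), a lower number less inhibition), the highest of the three numbers recorded there. Compound 2 `COc1cc(C2NC(=S)NC(c3ccc(C)cc3)=C2CCC(=O)O)cc(OC)c1OC` gives 20.5% in this assay, and compound 1 `O=C(O)CCC1=C(c2ccc(Cl)cc2)NC(=S)NC1c1ccccc1O` gives 9.61% in this assay. The only single-point step among these is the one in which hydrogen replaces chloro on an aromatic carbon, which gives a number 23.4 percentage points higher from compound 1 to compound 3 (beyond the scatter).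

Compound 4 `COc1ccc(C2=C(CCC(=O)O)C(c3ccccc3O)NC(=S)N2)cc1` differs from compound 3 by methoxy in place of hydrogen on an aromatic carbon. Going by the values given here, no measured pair differs by methoxy in place of hydrogen on an aromatic carbon alone, so no step in this assay bears directly on this change. Compound 2 carries methoxy groups but differs from compound 3 in several places, and its value only shows that a methoxy-bearing member of this series stays in the same broad region. With nothing more to go on, the step from compound 3 to compound 4 in this assay is expected to be small, a number 3 percentage points lower from compound 3 to compound 4 (within the scatter). Compound 4 is therefore estimated at 30% in this assay, within a range from 14% to 46%.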

Compound 4, a percentage reported as inhibition, in the whole organism at one dose (the size of the read-out at that dose, not a potency): 28.3%
Estimate against measurement, compound 4: 1.7 percentage points above; the range from low to high includes it.
By their numbers in this assay, from the lowest: compound 1; then compounds 2, 4 and 3 (each within the scatter of the next, the first and the last beyond it).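

In this assay the change from phenyl to 4-methoxyphenyl, on an aromatic carbon para to a large group, gives a number 4.7 percentage points lower from compound 3 to compound 4 (within the scatter) and so leaves methoxy and hydrogen at this place within the usual scatter of each other. Methoxy in place of chloro at the same place gives a number 18.7 percentage points higher from compound 1 to compound 4 (beyond the scatter) and this step stands alongside a number 23.4 percentage points higher from compound 1 to compound 3 (beyond the scatter) so that chloro is now the one of these three groups that stands apart, where the earlier compounds had shown only that it differs from hydrogen.

Going by these compounds, whether an amine or a nitrile at this place would read like hydrogen and methoxy or like chloro remains open. Nothing given here explains why chloro stands apart from the other two groups.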